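From benzyl to 4-chlorobenzyl in compound 4

This account rests on a few compounds, and the source may have more. Where it says the series, first, only, none or still open, it means among the compounds named here.

Values in a functional assay on HepG2 cells (Homo sapiens) for inhibition, read by WST assay, with stated times of 72 h and 2 h (on this read-out lower numbers stand for stronger inhibition and higher numbers for weaker inhibition), so far
Compound 1 `OC(c1cccs1)c1cc2ccccc2nc1Cl` gives 80800 nM
Compound 2 `C#CCOC(c1cccs1)c1cc2ccccc2nc1Cl` gives > 100000 nM
Compound 3 `Clc1nc2ccccc2cc1C(OCc1ccccc1)c1cccs1` gives "not active" (no number reported)
Compound 4 `Clc1ccc(COC(c2cccs2)c2cc3ccccc3nc2Cl)cc1` is not yet measured

Compound 3 is reported as "not active" (no number reported) without any number. Compound 2 gives > 100000 nM as a limit and not a number. Going on to compound 4 brings chloro in place of hydrogen on an aromatic carbon with chloro in place of hydrogen on an aromatic carbon and benzyl becoming 4-chlorobenzyl. For the measured compounds named here, the only measured step is an at least 1.2-fold higher number from compound 1 to compound 2 (0.09 log units; that floor lies within the scatter) and it concerns a different change, propargyl in place of hydrogen on an oxygen, so it bears on this one only loosely. Going by the values given here, no large step is therefore expected in this assay. Compound 1 at 80800 nM fits that expectation of weak activity. Compound 4 is expected at 70000 nM with an estimated range from 20000 nM up to 200000 nM at its top.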

Compound 4, half-maximal inhibitory concentration: "not active" (no number reported)
Compound 4: no number reported, and the estimate cannot be compared.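

For the compounds shown here, compound 3 and compound 4 are both reported as not active without a number, so no step from benzyl to 4-chlorobenzyl can be read. The compounds shown leave open whether this chloro changes the activity at all.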